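Swapping methylamino for methyl and what cytotoxicity may follow

A few compounds are considered here, and "the series" means these few. Any claim that something is new, unique, unknown or untested is made for them only; others in the source may bear on it.

Measured compounds:
- compound 1, `CNCc1ccc2c(c1)nc(Cn1c(=O)n(C(C)C)c3ccccc31)n2CCC(C)C`: 1480 nM
- compound 2, `CC(C)CCn1c(Cn2c(=O)n(CC(=O)OC(C)(C)C)c3ccccc32)nc2cc(C(=N)N)ccc21`: 7900 nM
- compound 3, `CC(C)CCn1c(Cn2c(=O)n(C(C)C)c3ccccc32)nc2ccc(CN(C)C)cc21`: 26700 nM

All three share one core and were tested in an ADME assay on HEp-2 cells (Homo sapiens) for cytotoxicity; a lower number here means that less compound is tolerated, a higher number that more compound is tolerated. Among them compound 1 gives the lowest number, 1480 nM, so it is the least tolerated of the three; compound 2 gives 7900 nM and compound 3 gives 26700 nM, both well beyond the scatter above compound 1. Going by the values given here, none of these three differs from another in just one place, so no single structural step between them can be read off.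

Compound 4, `CCc1ccc2c(c1)nc(Cn1c(=O)n(C(C)C)c3ccccc31)n2CCC(C)C`, is not yet measured. It differs from compound 1 in one place: methyl in place of methylamino on a saturated chain carbon bound to an aromatic carbon.

No comparable change has been measured here, so the size of the step is uncertain. A small to moderate rise in the tolerated concentration is expected, and the step from compound 1 to compound 4 is estimated at a 2.4-fold higher number from compound 1 to compound 4 (0.37 log units; beyond the scatter). For compound 4 a half-maximal cytotoxic concentration of about 3500 nM is expected, with a likely range from 900 nM to 14000 nM.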

Compound 4, half-maximal cytotoxic concentration: 18500 nM
Compound 4: middle estimate off by 5.3-fold (0.72 log units), on the low side; the measured number lies above the stated range.
By their numbers in this assay, from the lowest: compound 1; then compound 2; then compounds 4 and 3 (each within the scatter of the next).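

In this assay, going by these compounds alone, putting methyl in place of methylamino on a saturated chain carbon bound to an aromatic carbon gives a 13-fold higher number from compound 1 to compound 4 (1.10 log units; beyond the scatter), a large step and the first comparison here between compounds that differ in only one place. It shows that this single position can by itself shift the tolerated concentration by a wide margin, with the hydrogen-bond donor and acceptor counted on methylamino absent from methyl. No supporting measurement is available to explain the size of this step.

Going by these compounds, whether a hydroxyl group or a primary amine in the same place would behave more like methylamino or more like methyl remains open. It is also unknown whether the same swap would give a step of similar size on a different core.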